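The compounds below may be only part of what the source reports. "The series", "measured", "known", "first", "only" and "open" are said of these compounds alone.

Three nucleoside-like compounds share one core and differ at two positions. Compound 1 `COc1ncnc2c1c(-c1ccsc1)cn2[C@@H]1O[C@H](CO)[C@@H](O)[C@H]1O` gives 2570 nM in a functional assay on CCRF-CEM cells (Homo sapiens), read by MTT assay, with a stated time of 72 h; a higher number here means a weaker inhibitor, a lower number a stronger inhibitor. Compound 2 `CNc1ncnc2c1c(-c1ccsc1)cn2[C@@H]1O[C@H](CO)[C@@H](O)[C@H]1O` reaches only the limit of > 20000 nM in this assay, at which 1 of the 3 values shown sits, in this assay, so its value of > 20000 nM is a limit and not a number. Compound 3 `CNc1ncnc2c1c(-c1ccco1)cn2[C@@H]1O[C@H](CO)[C@@H](O)[C@H]1O` gives 180 nM in this assay, the lowest number of the three. Exchanging the group on the six-membered ring produced an at least 7.7-fold lower number from compound 2 to compound 1 (0.89 log units; beyond the scatter), while exchanging the five-membered ring on the core produced an at least 110-fold lower number from compound 2 to compound 3 (2.04 log units; beyond the scatter).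

Compound 4 `COc1ncnc2c1c(-c1ccco1)cn2[C@@H]1O[C@H](CO)[C@@H](O)[C@H]1O` is not yet measured. It differs from compound 3 by methoxy in place of methylamino on an aromatic carbon, the same change already seen from compound 2 to compound 1, where it was methoxy in place of methylamino on an aromatic carbon. The cores of compound 2 and compound 3 differ by furan-2-yl in place of thiophen-3-yl on an aromatic carbon. Since the earlier step of this change was an at least 7.7-fold lower number from compound 2 to compound 1 (0.89 log units; beyond the scatter), and rested on a limit, compound 4 is expected to give a lower number than compound 3 by about a 2.3-fold lower number from compound 3 to compound 4 (0.35 log units; beyond the scatter). The estimate for compound 4 in this assay is 80 nM, between 15 nM and 600 nM.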

Compound 4, half-maximal inhibitory concentration: 20 nM
Beside the measured number, compound 4's estimate is 4.0-fold (0.60 log units) above it; low and high end bracket the measured number.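

Methoxy in place of methylamino gave a 9.0-fold lower number from compound 3 to compound 4 (0.95 log units; beyond the scatter), and furan-2-yl in place of thiophen-3-yl gave a 130-fold lower number from compound 1 to compound 4 (2.11 log units; beyond the scatter), so in this assay each change lowered the number on both of the cores where it can be followed, which shows that the direction carried over but does not settle whether the size did. For the methoxy change, the comparison reads: the same change on two cores in this assay, an at least 7.7-fold lower number (0.89 log units; beyond the scatter) from compound 2 to compound 1 and a 9.0-fold lower number (0.95 log units; beyond the scatter) from compound 3 to compound 4; the limit leaves it open whether they differ For the furan-2-yl change, it reads: the same change on two cores in this assay, an at least 110-fold lower number (2.04 log units; beyond the scatter) from compound 2 to compound 3 and a 130-fold lower number (2.11 log units; beyond the scatter) from compound 1 to compound 4; the limit leaves it open whether they differ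

The compounds shown hold only two groups at each of the two places, so it remains open whether an amine or a longer chain such as ethoxy on the six-membered ring, or thiophen-2-yl or a phenyl ring in place of furan-2-yl, would follow the same direction. Also open, going by these compounds, is whether these steps would hold on a third core or in cells other than those tested here.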